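The source may hold more compounds than are shown below. What is called first, only, known or untested is meant among the compounds shown, and "the series" means these compounds.

Of the compounds shown here, two of a shared core have been measured in an assay on isolated protein for displacement of a labelled ligand from metabotropic glutamate receptor 5 (Homo sapiens), with a stated time of 60 min, tested at 1 uM; on this read-out higher numbers stand for more inhibition at the one concentration tested (going by the name of the read-out) and lower numbers for less inhibition. Compound 1, `Cc1ccc(S(=O)(=O)c2cnc3ccc(Cl)cc3c2N2CCC(C)CC2)cc1C`, gives 84% in this assay. Compound 2, `COc1ccc(S(=O)(=O)c2cnc3cc(Cl)ccc3c2N2CCC(C)CC2)cc1Cl`, gives 93% in this assay. The two numbers lie within the usual scatter of each other, so although compound 2 has the higher figure on paper, the inhibition in this assay is to be read as level for the pair.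

Compound 3, `CC1CCN(c2c(S(=O)(=O)c3ccc(Cl)c(Cl)c3)cnc3cc(Cl)ccc23)CC1`, has not yet been measured. It differs from compound 2 in one place: chloro in place of methoxy on an aromatic carbon. Among the compounds with values here, no step between measured compounds shows what such a change does here, so any expectation must rest on compound 2 alone. Compound 3 is expected to stay close to compound 2, with an estimated step of a number 5 percentage points lower from compound 2 to compound 3 (within the scatter), no larger than the scatter. The expected value for compound 3 is 88%, within a range from 70% to 98%.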

Compound 3, a percentage reported as inhibition, at one concentration (the size of the read-out at that concentration, not a potency): 89%
The estimate for compound 3 lay 1 percentage points below the measured number, and the stated range covers the measured number.
By their numbers in this assay, from the lowest: compounds 1, 3 and 2 (each within the scatter of the next).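

Replacing the methoxy with chloro, on the ring carbon ortho to a chloro group and para to a large group, gives a number 4 percentage points lower from compound 2 to compound 3 (within the scatter) in this assay, so the two compounds read as level. Within the data shown here, this is the first direct look at this position, and it shows that, within this pair, going from 3-chloro-4-methoxyphenyl to 3,4-dichlorophenyl leaves the inhibition at the one tested concentration intact, so the methoxy is not needed to keep it. No supporting measurement is available to explain why the swap leaves the figure level.

As far as these compounds go, whether a longer chain such as ethoxy, an amine or a carboxylic acid would be accepted at this same position remains open. A reading at one concentration also leaves open whether compound 2 and compound 3 match in potency.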